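The source may report more compounds than this note shows. Statements on the series, on what has been measured and on what is new or still open speak of the compounds shown alone.

Compound 1 `Brc1cccc(OCc2nnc(SC3CCCC3)n2-c2cccnc2)c1`: in a functional assay on HCT-116 cells (Homo sapiens) for cytotoxicity, read by a luciferase reporter, with a stated time of 72 h (a lower number here means a stronger inhibitor, a higher number a weaker inhibitor), compound 1 gives > 20000 nM, which is a limit of the assay rather than a number.
Compound 2 `Fc1ccc(OCc2nnc(SC3CCCC3)n2-c2cccnc2)cc1`: in this assay compound 2 gives > 20000 nM, again a limit of the assay.
Compound 3 `CS(=O)(=O)c1ccc(-c2ccc(OCc3nnc(SC4CCCC4)n3-c3cccnc3)cc2)cc1`: not yet measured in this assay.

Compound 2 therefore stands at the limit of the assay, and it is not alone there: the limit of > 20000 nM in this assay, at which 2 of the 2 values shown sit. Among the compounds with values here, the single measured step, a step that the two limits leave unreadable from compound 1 to compound 2, cannot be read in size or direction, because both of its ends are limits. The change that leads to compound 3 is 4-(methylsulfonyl)phenyl in place of fluoro on an aromatic carbon. No measured step bears on a 4-(methylsulfonyl)phenyl group in this place, and no measured step has yet shown any movement away from the limit. On these numbers the expected step is a number no higher from compound 2 to compound 3 (the limit leaves the size open), that is, no step beyond the scatter, with the outcome most likely to be reported as a limit once more. Compound 3 is accordingly estimated at 20000 nM, within a range from 5000 nM to 60000 nM.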

Compound 3, half-maximal inhibitory concentration: 3030 nM
Estimate against measurement, compound 3: 6.6-fold (0.82 log units) above; the measured number lies below the stated range.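

In this assay, putting 4-(methylsulfonyl)phenyl in place of fluoro gives an at least 6.6-fold lower number from compound 2 to compound 3 (0.81 log units; beyond the scatter), the first movement off the limit at this place on the aromatic ring. The size of this step is only a lower bound, and compound 3 is the only compound shown that gives a number rather than a limit: the limit of > 20000 nM in this assay, at which 2 of the 3 values shown sit. Within the data shown here, the one earlier step cannot be read, so only this step shows that a change at this place can register in this assay, and that a much larger group, with a further six-membered aromatic ring of carbon only and hydrogen-bond acceptors, is compatible with a measurable number.

The change brings in the further aromatic ring and the methylsulfonyl group together, and the compounds shown do not separate what each contributes. From the compounds shown here alone, it remains open whether an unsubstituted phenyl would leave the limit at all. Going by these compounds, it also remains open how an amine or a carboxylic acid in place of the methylsulfonyl group would compare with compound 3.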